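Butyl for tert-butyl on the triazole of compound 1

This account rests on a few compounds, and the source may have more. Where it says the series, first, only, none or still open, it means among the compounds named here.

Compound 1 `CC(C)(C)c1cn(C[C@H](O)[C@H]2OC(=O)C(OCc3ccccc3)=C2OCc2ccccc2)nn1` gives 28300 nM in a functional assay on HCT-116 cells (Homo sapiens) for antiproliferative activity, read by MTT assay, with a stated time of 72 h; a higher number here means a weaker inhibitor, a lower number a stronger inhibitor.
Compound 2 `Cc1ccc(S(=O)(=O)NCc2cn(C[C@H](O)[C@H]3OC(=O)C(OCc4ccccc4)=C3OCc3ccccc3)nn2)cc1` gives 13100 nM in this assay.
Compound 3 `C[Si](C)(C)c1cn(C[C@H](O)[C@H]2OC(=O)C(OCc3ccccc3)=C2OCc2ccccc2)nn1` gives 31800 nM in this assay.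

Among the three measured compounds, compound 1 stands with the second highest number; its nearest neighbour is compound 3, with a 1.1-fold higher number from compound 1 to compound 3 (0.05 log units; within the scatter), and its furthest is compound 2, with a 2.2-fold lower number from compound 1 to compound 2 (0.33 log units; beyond the scatter). Compound 1 and compound 3 are thus indistinguishable within the scatter, while compound 2 sits modestly apart from both, as a 2.4-fold higher number from compound 2 to compound 3 (0.39 log units; beyond the scatter) also shows.

Compound 4 `CCCCc1cn(C[C@H](O)[C@H]2OC(=O)C(OCc3ccccc3)=C2OCc2ccccc2)nn1` differs from compound 1 in one place: butyl in place of tert-butyl on an aromatic carbon. Two measured steps leave the same position of the shared core, both starting from the tert-butyl of compound 1. The exchange for trimethylsilyl in compound 3 changed nothing beyond the scatter, and the exchange for the much larger sulfonamide-bearing group in compound 2 gave only a modest step. Neither step replaces tert-butyl with a chain of the same atoms, so the bearing is indirect, but both point to this position tolerating change with little effect. Compound 4 is therefore expected to give about 27000 nM in this assay, between 12000 nM and 60000 nM, which means an expected step of a 1.0-fold lower number from compound 1 to compound 4 (0.02 log units; within the scatter), not beyond the scatter.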

Compound 4, half-maximal inhibitory concentration: 10400 nM
Beside the measured number, compound 4's estimate is 2.6-fold (0.41 log units) above it; the measured number lies below the stated range.
By their numbers in this assay, from the lowest: compounds 4 and 2 (each within the scatter of the next); then compounds 1 and 3 (each within the scatter of the next).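

Rearranging the same carbon atoms from tert-butyl to butyl on the aromatic carbon moves the result in this assay by a 2.7-fold lower number from compound 1 to compound 4 (0.43 log units; beyond the scatter), so this position is less indifferent than the exchange of tert-butyl for trimethylsilyl alone had suggested. The exchange of trimethylsilyl for butyl tells the same story, at a 3.1-fold lower number from compound 3 to compound 4 (0.49 log units; beyond the scatter), which leaves the two branched groups of compound 1 and compound 3 together on one side of butyl. Compound 2 and compound 4 cannot be told apart, at a 1.3-fold lower number from compound 2 to compound 4 (0.10 log units; within the scatter), so a plain butyl chain reaches the same level as the far larger (((4-methylphenyl)sulfonyl)amino)methyl group, which carries an aromatic ring that butyl lacks.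

The compounds shown leave open whether the branching itself or the length of the chain matters here, a question that a propyl group, an isobutyl group or a longer chain such as hexyl would address. They also leave open how a butyl-length chain ending in an amine or a carboxylic acid would read in this assay, and nothing at hand accounts for any of these steps.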